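Difluoro anilino change at the cytotoxicity limit

This account rests on a few compounds, and the source may have more. Where it says the series, first, only, none or still open, it means among the compounds named here.

In a functional assay on NALM-6 cells (Homo sapiens) for cytotoxicity, with a stated time of 72 h (on this read-out higher numbers stand for an effect only at larger amounts of compound and lower numbers for an effect already at smaller amounts), compound 2 (`C=C[C@@](C)(/C=C/c1ccc(Nc2ccccc2)cc1)CCC=C(C)C`) gives > 43400 nM as a limit, not a number. Compound 1 (`C=C[C@@](C)(/C=C/c1ccc(O)c(/C=C/c2ccc(Cl)cc2)c1)CCC=C(C)C`) gives > 43400 nM as a limit too. Compound 3 (`C=C[C@@](C)(/C=C/c1ccc(Nc2cccc(OC(F)(F)F)c2)cc1)CCC=C(C)C`) gives > 43400 nM as a limit too. Compound 2 therefore has no readable place in the series, and the limit of > 43400 nM in this assay, at which 3 of the 3 values shown sit, applies across the set. Compound 4 (`C=C[C@@](C)(/C=C/c1ccc(Nc2cc(F)cc(F)c2)cc1)CCC=C(C)C`) has 3,5-difluorophenyl in place of phenyl on a nitrogen on an aromatic ring, with 3,5-difluorophenyl in place of phenyl on a nitrogen on an aromatic ring as the counted change. Within the data shown here, the only measured step bearing on it is a step that the two limits leave unreadable from compound 2 to compound 3 and it offers no size to carry over. No step beyond the scatter is expected in this assay in either direction. The expected step is a number no higher from compound 2 to compound 4 (the limit leaves the size open) and it is estimated from limits alone. For compound 4 the estimate is 43400 nM with an expected range of 20000 nM to 43400 nM and a limit is the likeliest report.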

Compound 4, half-maximal effective concentration: > 43400 nM
Compound 4 was reported as a limit; the forecaster's own chance of this, stated with the estimate: 85%; the middle value lies on the limit itself.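

No step can be read from compound 2 to compound 4, as both are reported only as limits: the limit of > 43400 nM in this assay, at which 4 of the 4 values shown sit.

The compounds shown leave open at what concentration any of them acts in this assay, and whether 3,5-difluorophenyl in place of phenyl alters that.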